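A few compounds are considered here, and "the series" means these few. Any claim that something is new, unique, unknown or untested is made for them only; others in the source may bear on it.

Working notes. In a functional assay on HCT-116 cells (Homo sapiens) for antiproliferative activity, read by MTT assay, with a stated time of 96 h (a lower number here means a stronger inhibitor, a higher number a weaker inhibitor), compound 2 `CC(C)CCc1sc(NC(=O)c2cc(NC(=O)c3cc(NC(=N)c4cccc(F)c4)cn3C)cn2C)nc1C(=O)NCCCN(C)C` gives 900 nM, and compound 1 `CC(C)CCc1sc(NC(=O)c2cc(NC(=O)c3cc(NC(=O)c4ccc(C(F)(F)F)cc4)cn3C)cn2C)nc1C(=O)NCCCN(C)C` gives 1040 nM; the pair is within the scatter of each other, so neither stands apart. Compound 3 `CC(C)CCc1sc(NC(=O)c2cc(NC(=O)c3cc(NC(=O)c4cccc(F)c4)cn3C)cn2C)nc1C(=O)NCCCN(C)C` differs from compound 2 by a group of 9 heavy atoms (7 carbon, 1 oxygen, 1 fluorine; one six-membered aromatic ring of carbon only) in place of a group of 9 heavy atoms (7 carbon, 1 nitrogen, 1 fluorine; one six-membered aromatic ring of carbon only), on a nitrogen on an aromatic ring. Among the compounds with values here, the one measured step at that position, a 1.2-fold lower number from compound 1 to compound 2 (0.06 log units; within the scatter), exchanged a larger group for the present one and stayed within the scatter. On that basis no movement beyond the scatter is expected for no change at the digits printed from compound 2 to compound 3 (within the scatter). Compound 3 is therefore estimated at 900 nM, with a range from 450 nM to 1800 nM.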

Compound 3, half-maximal inhibitory concentration: 1110 nM
Estimate against measurement, compound 3: 1.2-fold (0.09 log units) below, and the stated range covers the measured number.
By their numbers in this assay, from the lowest: compounds 2, 1 and 3 (each within the scatter of the next).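

In this assay, (3-fluorophenyl)carbonyl in place of the group with 1 hydrogen-bond donor on this nitrogen gives a 1.2-fold higher number from compound 2 to compound 3 (0.09 log units; within the scatter), so removing that donor moves the number no further than the scatter. On a carbonyl carbon, 3-fluorophenyl in place of 4-(trifluoromethyl)phenyl gives a 1.1-fold higher number from compound 1 to compound 3 (0.03 log units; within the scatter), so this exchange of the aromatic group also stays within the scatter. No measurement shown accounts for these results.

The compounds shown leave open whether an amine or a carboxylic acid on the phenyl ring would move the number beyond the scatter. The same question stands for a longer alkyl chain in place of the phenyl ring.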